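Thiazole acetic acids: biphenyl replacing fluorophenyl

The source may report more compounds than this note shows. Statements on the series, on what has been measured and on what is new or still open speak of the compounds shown alone.

Compound 1 `O=C(O)Cc1sc(Nc2ccc(Cl)cc2)nc1-c1ccc(F)cc1` and compound 2 `O=C(O)Cc1sc(-c2ccccc2)nc1-c1ccc(F)cc1` share the core and the acetic acid; in an in vitro assay on COS-7 cells for displacement of a labelled ligand from prostaglandin D2 receptor 2 (Homo sapiens) (a higher number here means a weaker inhibitor, a lower number a stronger inhibitor), compound 1 gives 960 nM and compound 2 gives 860 nM. For the measured compounds named here, the only measured step, a 1.1-fold lower number from compound 1 to compound 2 (0.05 log units; within the scatter), concerns the other aromatic carbon of the core and leaves the two compounds within the scatter of each other, so neither can be ranked against the other on these numbers.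

Compound 3 `O=C(O)Cc1sc(-c2ccccc2)nc1-c1ccc(-c2ccccc2)cc1` differs from compound 2 by phenyl in place of fluoro on an aromatic carbon. Going by the values given here, no measured step touches this position, so the measured step gives no direction for it; the series so far shows only that the replacement on the other side of the core left this assay unchanged. In the absence of bearing data, compound 3 is expected to give about 1000 nM, with a range of 300 nM to 4000 nM. The step from compound 2 is thus expected to be a 1.2-fold higher number from compound 2 to compound 3 (0.07 log units; within the scatter), with wide uncertainty.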

Compound 3, half-maximal inhibitory concentration: 38 nM
Estimate against measurement, compound 3: 26-fold (1.42 log units) above; the whole stated range lies above it.
By their numbers in this assay, from the lowest: compound 3; then compounds 2 and 1 (each within the scatter of the next).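

In this assay this position, on an aromatic carbon of a six-membered aromatic ring of carbon only, proves sensitive to substitution: phenyl in place of fluoro gives a 23-fold lower number from compound 2 to compound 3 (1.35 log units; beyond the scatter). For the compounds shown here, the only earlier step, a 1.1-fold lower number from compound 1 to compound 2 (0.05 log units; within the scatter), lay on the other side of the core and within the scatter, so compound 3 is the first sign that the series can move in this assay, and it does so with a group that carries no hydrogen-bond donors or acceptors. Nothing available explains the size of this step.

Open, going by these compounds, is whether a whole phenyl ring is required here, or whether a methoxy group, a chloro group or a phenyl bearing an amine would serve as well. Also open, on these data alone, is whether the same change holds with the (4-chlorophenyl)amino group of compound 1 on the other side of the core.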